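Swapping the aryl ether of compound 1 for an aryl thioether

The source may hold more compounds than are shown below. What is called first, only, known or untested is meant among the compounds shown, and "the series" means these compounds.

Compound 1 `Nc1cc(N)c2nc(-c3ccccc3)c(Oc3ccc(Cl)c(Cl)c3)nc2c1`: 15100 nM
Compound 2 `Nc1cc(N)c2nc(-c3ccccc3)c(NCc3ccc(Cl)c(Cl)c3)nc2c1`: 22400 nM
Compound 3 `CCOC(=O)[C@H](CCC(=O)O)NC(=O)c1ccc(Sc2nc3cc(N)cc(N)c3nc2-c2ccccc2)cc1`: 17800 nM

Of the compounds shown here, three sharing one core have been measured in a functional assay on NCI-H226 cells (Homo sapiens) for inhibition, read by sulforhodamine B assay, with a stated time of 48 h; on this read-out higher numbers stand for weaker inhibition of growth and lower numbers for stronger inhibition of growth. Compound 1 gives 15100 nM, compound 3 gives 17800 nM and compound 2 gives 22400 nM. Compound 1 has the lowest of the three numbers, but its nearest neighbour, compound 3, and its furthest, compound 2, both lie within the scatter of it, so the three cannot be told apart on these data.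

Compound 4 `Nc1cc(N)c2nc(-c3ccccc3)c(Sc3ccc(F)cc3)nc2c1` has not yet been measured in this assay. It differs from compound 1 in one place: (4-fluorophenyl)sulfanyl in place of 3,4-dichlorophenoxy on an aromatic carbon. The point of attachment on the core is unchanged; only the group hanging from that aromatic carbon is different.

For the measured compounds named here, no pair of measured compounds differs in a single place, so no measured step is available to guide the expectation. What is known is that three different groups at this position of the core, including a sulfanyl link in compound 3, all gave numbers within the scatter of one another. On that basis the step of a 1.1-fold higher number from compound 1 to compound 4 (0.03 log units; within the scatter) is expected to stay within the scatter, with no clear direction. Compound 4 is therefore estimated to give 16000 nM, with a range from 6000 nM to 45000 nM.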

Compound 4, concentration for 50% growth inhibition: 19100 nM
Compound 4: the middle estimate sits 1.2-fold (0.08 log units) below what was measured, within the range that was stated.
By their numbers in this assay, from the lowest: compounds 1, 3, 4 and 2 (each within the scatter of the next).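

In this assay, for the compounds shown here, putting (4-fluorophenyl)sulfanyl in place of 3,4-dichlorophenoxy gives a 1.3-fold higher number from compound 1 to compound 4 (0.10 log units; within the scatter), and this is the first comparison at this position in which only one group differs. It shows that, on this aromatic carbon next to the ring nitrogen and ortho to a phenyl group, an oxygen-linked dichlorophenyl and a sulfur-linked fluorophenyl cannot be told apart on this read-out, even though the link atom and the substituents on the aromatic ring differ together. No measurement is available here that bears on why the two groups read alike.

From the compounds shown here alone, because the link atom and the ring substituents differ together in this one step, it remains open whether either change alone would leave the read-out within the scatter, or whether two separate effects happen to offset each other; 3,4-dichlorophenylsulfanyl, which pairs the ring of compound 1 with the sulfur link of compound 4, would separate them. Going by these compounds, it is also open whether the insensitivity seen so far extends to a group of a different kind at this carbon, such as a piperazine.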